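Methoxy for Trifluoromethyl on the Core of Compound 1

The source may hold more compounds than are shown below. What is called first, only, known or untested is meant among the compounds shown, and "the series" means these compounds.

Measured compounds:
compound 1 `Cn1c(CN2CCN(c3nc(Cl)ccc3C(F)(F)F)CC2)nc2cc(C(F)(F)F)ccc21` — 2000 nM
compound 2 `Cn1c(CN2CCC(c3ccccc3)CC2)nc2ccccc21` — 200 nM
compound 3 `Cn1c(CN2CCC(c3ccc(Cl)cc3)CC2)nc2ccccc21` — 79.4 nM

In an assay on CHO cells with metabotropic glutamate receptor 2 (Homo sapiens) as the target, read by FLIPR (on this read-out lower numbers stand for an effect already at smaller amounts and higher numbers for an effect only at larger amounts of compound), compound 1 gives 2000 nM, the highest of the three numbers. Compound 2 gives 200 nM and compound 3 gives 79.4 nM, both lower than compound 1 by gaps that lie beyond the scatter. Among the compounds with values here, the one step between compounds that differ in a single place is a 2.5-fold lower number from compound 2 to compound 3 (0.40 log units; beyond the scatter), a chloro in place of hydrogen on an aromatic carbon.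

Compound 4 `COc1ccc2c(c1)nc(CN1CCN(c3nc(Cl)ccc3C(F)(F)F)CC1)n2C` differs from compound 1 by methoxy in place of trifluoromethyl on an aromatic carbon of a six-membered aromatic ring of carbon only, part of a fused system of two rings, meta to a fused ring and para to a fused ring. Within the data shown here, no measured step touches this place or this pair of groups. The step from compound 2 to compound 3 concerns another part of another core, and compounds 2 and 3 do not share the core of compound 1, so it offers only a general hint that a single aromatic substituent change can shift the number modestly. With nothing that points one way, the expected change from compound 1 to compound 4 is no change at the digits printed from compound 1 to compound 4 (within the scatter), which is taken as no step beyond the scatter. Compound 4 is estimated at 2000 nM, with a range from 600 nM to 6500 nM.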

Compound 4, half-maximal effective concentration: 251 nM
Beside the measured number, compound 4's estimate is 8.0-fold (0.90 log units) above it, and the stated range ends above it.
By their numbers in this assay, from the lowest: compound 3; then compounds 2 and 4 (each within the scatter of the next); then compound 1.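

In this assay, replacing trifluoromethyl with methoxy on the shared core gives an 8.0-fold lower number from compound 1 to compound 4 (0.90 log units; beyond the scatter). This shows that the number responds to the group on this aromatic carbon of a six-membered aromatic ring of carbon only, part of a fused system of two rings, something the earlier step, chloro in place of hydrogen on another core, could not show. The exchange swaps a group with 0 hydrogen-bond acceptors for one with 1, but no measurement here links that difference, or any other feature of the two groups, to the shift in the number.

Within the data shown here, the single pair leaves open whether the lower number follows from the presence of methoxy or from the absence of trifluoromethyl, a question that hydrogen, hydroxy, ethoxy or an amine at the same place would help to separate. It also leaves open whether the same exchange would shift the number to a similar extent with the other parts of the molecule changed, for instance on the core of compound 2.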